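A Chlorophenyl Returns on the Tetrabromo Core

The source may hold more compounds than are shown below. What is called first, only, known or untested is meant among the compounds shown, and "the series" means these compounds.

Compound 3 `CC(O)CCn1nc2c(Br)c(Br)c(Br)c(Br)c2n1` stands level with compound 1 `OC(CCn1nc2c(Br)c(Br)c(Br)c(Br)c2n1)c1cccc(Br)c1` at the digits shown, the two together forming the lowest of three values: in a functional assay on MCF7 cells (Homo sapiens) for antiproliferative activity, read by MTT assay, with a stated time of 48 h, tested at 100 uM (a lower number here means a stronger effect, a higher number a weaker effect of the compound at the concentration tested), compound 3 gives 0% and compound 1 gives 0%, while compound 2 `OC(CCn1nc2c(Br)c(Br)c(Br)c(Br)c2n1)c1cccc(Cl)c1` gives 0.5%. The change to compound 4 `OC(CCn1nc2c(Br)c(Br)c(Br)c(Br)c2n1)c1ccc(Cl)cc1` is 4-chlorophenyl in place of methyl on a saturated chain carbon bound to an oxygen on a saturated carbon and a saturated chain carbon. Among the measured compounds shown here, two measured steps bear on it, each trading an aryl group for methyl at the same place: no change at the digits printed from compound 1 to compound 3 (within the scatter) and a number 0.5 percentage points lower from compound 2 to compound 3 (within the scatter). The halogen exchange a number 0.5 percentage points higher from compound 1 to compound 2 (within the scatter) was likewise within the scatter. Given a number 0.5 percentage points lower from compound 2 to compound 3 (within the scatter), compound 4 is expected to move by a number 1 percentage points higher from compound 3 to compound 4 (within the scatter) in this assay, nothing beyond the scatter. The estimate for compound 4 is 1%, between 0% and 12%.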

Compound 4, a percentage reported as activity, at one concentration (the size of the read-out at that concentration, not a potency): 0%
Compound 4: middle estimate off by 1 percentage points, on the high side; the range from low to high includes it.
By their numbers in this assay, from the lowest: compounds 1, 3, 4 and 2 (each within the scatter of the next).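

In this assay, 4-chlorophenyl in place of methyl gives no change at the digits printed from compound 3 to compound 4 (within the scatter), so a third aryl group at this place leaves the read-out where methyl had it. Replacing 3-chlorophenyl with 4-chlorophenyl gives a number 0.5 percentage points lower from compound 2 to compound 4 (within the scatter), and replacing 3-bromophenyl with 4-chlorophenyl gives no change at the digits printed from compound 1 to compound 4 (within the scatter), so this change of halogen placement also stays within the scatter. No measurement shown offers a reason for these flat results.

On these data alone, whether an amine or a carboxylic acid in place of the aryl group, or a longer chain, would move the read-out beyond the scatter remains open.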